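The source may report more compounds than this note shows. Statements on the series, on what has been measured and on what is new or still open speak of the compounds shown alone.

In a functional assay on A-375 cells (Homo sapiens) for inhibition, read by MTT assay, with a stated time of 4 days (on this read-out lower numbers stand for stronger inhibition and higher numbers for weaker inhibition), compound 1 `CN1C[C@@H]2CC[C@H]1CN2c1ccc(-c2ccnc3c(-c4cccc5[nH]ncc45)c(-c4ccncc4)nn23)c(F)c1` gives 118 nM and compound 2 `c1cc(-c2c(-c3ccncc3)nn3c(-c4ccc(CN5C[C@@H]6C[C@H]5CO6)cc4)ccnc23)c2cn[nH]c2c1` gives 945 nM, so compound 2 holds the higher of the two numbers, a gap beyond the scatter. Compound 3 `Fc1cc(CN2C[C@@H]3C[C@H]2CO3)ccc1-c1ccnc2c(-c3cccc4[nH]ncc34)c(-c3ccncc3)nn12` carries fluoro in place of hydrogen on an aromatic carbon of compound 2: fluoro in place of hydrogen on an aromatic carbon. Among the measured compounds shown here, no measured pair isolates this change, though compound 1 also bears a fluoro. A small move toward lower numbers in this assay is expected, possibly no larger than the scatter, and the estimated shift is a 1.7-fold lower number from compound 2 to compound 3 (0.24 log units; within the scatter). For compound 3 the estimated value is 550 nM, with an expected range of 180 nM to 1500 nM.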

Compound 3, half-maximal inhibitory concentration: 268 nM
Compound 3: middle estimate off by 2.1-fold (0.31 log units), on the high side, and the stated range covers the measured number.
By their numbers in this assay, from the lowest: compound 1; then compound 3; then compound 2.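

In this assay, fluoro in place of hydrogen on the aromatic carbon ortho to a large group gives a 3.5-fold lower number from compound 2 to compound 3 (0.55 log units; beyond the scatter), so this single atom change alone moves the number. With fluoro present in both compounds, the group of 8 heavy atoms in place of the group of 9 heavy atoms gives a 2.3-fold higher number from compound 1 to compound 3 (0.36 log units; beyond the scatter), so the side group also matters. Nothing at hand explains either step. From the compounds shown here alone, whether chloro or methoxy at this place would behave like fluoro remains open, as does whether the fluoro step would hold with the group of 9 heavy atoms.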